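The source may hold more compounds than are shown below. What is called first, only, known or untested is meant among the compounds shown, and "the series" means these compounds.

Values in a functional assay on A549 cells (Homo sapiens) for antiproliferative activity, read by MTT assay, with a stated time of 72 h; a lower number here means a stronger inhibitor, a higher number a weaker inhibitor

Compound 1 `C=CC(=O)Nc1cc(Nc2nccc(NC(=O)c3cccc(OC)c3)n2)c(OC)cc1N1CCN(C)CC1` gives 6450 nM
Compound 2 `C=CC(=O)Nc1cc(Nc2nccc(NC(=O)c3ccc(C(F)(F)F)cc3)n2)c(OC)cc1N1CCN(C)CC1` gives 7890 nM
Compound 3 `C=CC(=O)Nc1cc(Nc2nccc(NC(=O)c3ccccc3)n2)c(OC)cc1N(C)CCN(C)C` gives 1740 nM

Compound 3 has the lowest number of the three, and its gaps to the other two lie beyond the scatter. Compound 4 `C=CC(=O)Nc1cc(Nc2nccc(NC(=O)c3ccccc3)n2)c(OC)cc1N1CCN(C)CC1` has not been measured yet. It differs from compound 3 at one place, an aromatic carbon (4-methylpiperazin-1-yl in place of (2-(dimethylamino)ethyl)(methyl)amino on an aromatic carbon). For the measured compounds named here, the only measured step (a 1.2-fold higher number from compound 1 to compound 2 (0.09 log units; within the scatter)) changes a different part of the molecule, the group on the carbonyl carbon, and stays within the scatter. Going by the values given here, it therefore says little about this exchange, and no measured step isolates it.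

The closest evidence is indirect. Compound 1 at 6450 nM and compound 2 at 7890 nM both carry the incoming 4-methylpiperazin-1-yl group and read higher than compound 3, although they also differ from it on the carbonyl side. A move towards a higher number in this assay is therefore expected, probably beyond the scatter. The expected change is a 2.9-fold higher number from compound 3 to compound 4 (0.46 log units; beyond the scatter) and remains uncertain. Compound 4 is estimated at 5000 nM with an expected range (2200 nM to 9500 nM).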

Compound 4, half-maximal inhibitory concentration: 5970 nM
Compound 4: the middle estimate sits 1.2-fold (0.08 log units) below what was measured; low and high end bracket the measured number.
By their numbers in this assay, from the lowest: compound 3; then compounds 4, 1 and 2 (each within the scatter of the next).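

In this assay, the exchange on the aromatic carbon ortho to the (vinylcarbonyl)amino group can now be read alone: replacing the open (2-(dimethylamino)ethyl)(methyl)amino chain with the 4-methylpiperazin-1-yl ring gives a 3.4-fold higher number from compound 3 to compound 4 (0.54 log units; beyond the scatter). With that ring in place, the carbonyl side makes little difference, as hydrogen in place of trifluoromethyl gives a 1.3-fold lower number from compound 2 to compound 4 (0.12 log units; within the scatter) and hydrogen in place of methoxy gives a 1.1-fold lower number from compound 1 to compound 4 (0.03 log units; within the scatter), so among these compounds only the amine exchange moves the number beyond the scatter. No measurement here accounts for the effect of this exchange.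

Compound 3 is the only compound shown with the open chain, so it remains open whether the chain would keep its advantage alongside a methoxy or trifluoromethyl group on the carbonyl side. Going by these compounds, how a morpholin-4-yl ring or a simple dimethylamino group would read at this position also remains open.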